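A few compounds are considered here, and "the series" means these few. Any claim that something is new, unique, unknown or untested is made for them only; others in the source may bear on it.

Measured so far in a functional assay on KB cells (Homo sapiens) for antiproliferative activity, read by sulforhodamine B assay, with a stated time of 3 days; on this read-out lower numbers stand for an effect already at smaller amounts and higher numbers for an effect only at larger amounts of compound:
compound 1 `CCC1=C(O)c2c(oc(-c3ccc(CC)cc3)cc2=O)C(CC)(CC)C1=O` gives 21.9 uM;
compound 2 `CCC1=C(O)c2c(oc(-c3ccc(Br)cc3)cc2=O)C(CC)(CC)C1=O` gives only a limit, > 48.1 uM;
compound 3 `CCC1=C(O)c2c(oc(-c3ccc(OC)cc3C)cc2=O)C(CC)(CC)C1=O` gives 20.9 uM.

Compound 3 and compound 1 give numbers within the scatter of each other, as the step of a 1.0-fold lower number from compound 1 to compound 3 (0.02 log units; within the scatter) shows; compound 2 returns a limit (the limit of > 48.1 uM in this assay, at which 1 of the 3 values shown sits), and the step of an at least 2.3-fold lower number from compound 2 to compound 3 (0.36 log units; beyond the scatter) is beyond the scatter. Compound 4 `CCC1=C(O)c2c(oc(-c3cc(C)cc(C)c3)cc2=O)C(CC)(CC)C1=O` has not been measured. Its change from compound 3 is 3,5-dimethylphenyl in place of 4-methoxy-2-methylphenyl on an aromatic carbon. The nearest guide is the step of a 1.0-fold lower number from compound 1 to compound 3 (0.02 log units; within the scatter), where exchanging one aryl for another left the number within the scatter, so compound 4, carrying a 3,5-dimethylphenyl, is expected to give a step of a 1.1-fold higher number from compound 3 to compound 4 (0.02 log units; within the scatter) that stays within the scatter. Compound 4 is estimated at 22 uM, between 10 uM and 48 uM.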

Compound 4, concentration for half-maximal effect: 45.5 uM
Beside the measured number, compound 4's estimate is 2.1-fold (0.32 log units) below it; the measured number falls inside the stated range.
By their numbers in this assay, from the lowest: compounds 3 and 1 (each within the scatter of the next); then compound 4. At a limit, above all of these: compound 2.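

In this assay, this position proved sensitive to which substituents the aryl group carries: 3,5-dimethylphenyl gives a 2.2-fold higher number from compound 3 to compound 4 (0.34 log units; beyond the scatter) and a 2.1-fold higher number from compound 1 to compound 4 (0.32 log units; beyond the scatter), whereas exchanging 4-ethylphenyl for 4-methoxy-2-methylphenyl had given a 1.0-fold lower number from compound 1 to compound 3 (0.02 log units; within the scatter). Compound 2 stands only at a limit, so the step of an at least 1.0-fold lower number from compound 2 to compound 4 (0.02 log units; that floor lies within the scatter) is only a floor and cannot be read further: the limit of > 48.1 uM in this assay, at which 1 of the 4 values shown sits.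

The compounds shown leave open how an aryl group carrying an amine or a carboxylic acid would read out at this position. They also leave open what a longer chain in place of the aryl group would do.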